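Fluoro for methoxy on the shared core

The compounds below may be only part of what the source reports. "The series", "measured", "known", "first", "only" and "open" are said of these compounds alone.

Compound 1, `CN(C)S(=O)(=O)Nc1cccc2c1CCCC2c1c[nH]cn1`, 1580 nM in an assay on isolated protein for binding affinity to Alpha-1D adrenergic receptor (Rattus norvegicus), read by radioligand binding; a lower number here means a stronger inhibitor, a higher number a weaker inhibitor; compound 2, `COC(=O)Nc1cccc2c1CCCC2c1c[nH]cn1`, 3020 nM; compound 3, `COc1ccc(NS(C)(=O)=O)c2c1C(c1c[nH]cn1)CCC2`, < 10000 nM.

Compound 3 stands apart from the other two: its value in this assay is only a limit, (the limit of < 10000 nM in this assay, at which 1 of the 3 values shown sits), and not a number, so where it sits among the measured compounds cannot be said. Compounds 1 and 2 both carry a number; the step of a 1.9-fold higher number from compound 1 to compound 2 (0.28 log units; within the scatter) concerns the group on the nitrogen and lies within the scatter.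

Compound 4, `CS(=O)(=O)Nc1ccc(F)c2c1CCCC2c1c[nH]cn1`, differs from compound 3 in one place: fluoro in place of methoxy on an aromatic carbon. Within the data shown here, no measured step touches this position, since the one step that exists changes the nitrogen substituent and not the aromatic carbon, so the data give no direct guide to the size or direction of this change. Among the measured compounds shown here, the step of a 1.9-fold higher number from compound 1 to compound 2 (0.28 log units; within the scatter) shows only that a change elsewhere on the core stayed within the scatter.

Against this background the step from compound 3 to compound 4 is estimated as a step that the limit leaves unreadable from compound 3 to compound 4, with the starting point itself a limit. Compound 4 is therefore expected to give about 2500 nM in this assay, most likely between 600 nM and 9000 nM.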

Compound 4, inhibition constant: 3020 nM
The estimate for compound 4 lay 1.2-fold (0.08 log units) below the measured number; the measured number falls inside the stated range.
By their numbers in this assay, from the lowest: compounds 1, 2 and 4 (each within the scatter of the next).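

The limit that compound 3 carries in this assay leaves the step to compound 4 unreadable, so no new step can be read from this result: the limit of < 10000 nM in this assay, at which 1 of the 4 values shown sits.

The compounds shown leave open what fluoro in place of methoxy on an aromatic carbon does in this assay when both partners carry a measured number.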